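The source may report more compounds than this note shows. Statements on the series, on what has been measured and on what is new or still open speak of the compounds shown alone.

Measured compounds:
compound 1, `O=c1c(-c2ccc(O)cc2)coc2cc(CC3OC(CO)C(O)C(O)C3O)ccc12`: 0%
compound 2, `O=c1c(-c2ccc(O)cc2)coc2cc(OCCCCBr)ccc12`: 98.3%
compound 3, `O=C(O)CCCCCCCCCOc1ccc2c(=O)c(-c3ccc(O)cc3)coc2c1`: 95%

In a functional assay on mitochondria (Cricetulus griseus) for inhibition of Monoamine oxidase (Homo sapiens), tested at 9 uM (on this read-out lower numbers stand for a weaker effect and higher numbers for a stronger effect at the one concentration tested), compound 2 gives the highest of the three numbers. Compound 3 sits nearest, and the step of a number 3.3 percentage points lower from compound 2 to compound 3 (within the scatter) is within the scatter, so the two show no difference that can be read. For the measured compounds named here, compound 1 lies furthest off; no step between compound 2 and compound 1 is given, only the two values, and the gap between them is beyond the scatter.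

Compound 4, `O=c1c(-c2ccc(O)cc2)coc2cc(OCC(O)CO)ccc12`, has not yet been measured in this assay. It differs from compound 2 as follows: 1,2-dihydroxyethyl in place of 3-bromopropyl on a saturated chain carbon bound to an oxygen on an aromatic ring. Going by the values given here, the only measured step, from compound 2 to compound 3, concerns the far end of the same chain and is within the scatter; it does not speak to exchanging 3-bromopropyl for 1,2-dihydroxyethyl. Compound 1, with hydroxyl-bearing groups on its side chain, gives 0%, which leaves room for a drop. The step of a number 63.3 percentage points lower from compound 2 to compound 4 (beyond the scatter) is therefore expected to be downward, with wide uncertainty. Compound 4 is estimated at 35%, range 0% to 75%.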

Compound 4, a percentage reported as inhibition, at one concentration (the size of the read-out at that concentration, not a potency): 95.1%
Compound 4: the middle estimate sits 60.1 percentage points below what was measured; the whole stated range lies below it.
By their numbers in this assay, from the lowest: compound 1; then compounds 3, 4 and 2 (each within the scatter of the next).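

In this assay, exchanging the bromine-bearing chain for the diol gives a number 3.2 percentage points lower from compound 2 to compound 4 (within the scatter), so 1,2-dihydroxyethyl in place of 3-bromopropyl leaves no difference that can be read. The earlier step concerned only the far end of the chain; this one replaces the chain end nearer the oxygen on the aromatic ring as well, and compound 4 still gives a high number with no bromine and with 2 hydrogen-bond donors in the entering group. No measurement at hand offers an explanation for this result.

With compound 1 at 0%, the compounds shown do not settle which feature of its side chain goes with that value. As far as these compounds go, an amine or a much shorter chain on the same oxygen remains open, as does any difference among compounds 2, 3 and 4 in the strength of their effect at other concentrations, which a read-out at one concentration cannot give.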